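Removing the aminoalkyl chain from the chalcone series

The source may hold more compounds than are shown below. What is called first, only, known or untested is meant among the compounds shown, and "the series" means these compounds.

Compound 1 `CCN(CC)CCCOc1ccc(C(=O)/C=C/c2ccc(N(C)C)cc2)c(O)c1` is the strongest of the three measured analogues in an assay on isolated protein for inhibition of Amine oxidase [flavin-containing] B (Homo sapiens); a higher number here means a weaker inhibitor, a lower number a stronger inhibitor: compound 1 gives 4100 nM. Compound 2 `CCN(CCCOc1ccc(C(=O)/C=C/c2ccc(N(C)C)cc2)c(O)c1)Cc1ccccc1OC` gives 10800 nM and compound 3 `CCN(CCCOc1ccc(C(=O)/C=C/c2ccc(N(C)C)cc2)c(O)c1)Cc1ccc(N(C)C)cc1` gives 13700 nM; the corresponding steps are a 2.6-fold higher number from compound 1 to compound 2 (0.42 log units; beyond the scatter) and a 3.3-fold higher number from compound 1 to compound 3 (0.52 log units; beyond the scatter), while a 1.3-fold higher number from compound 2 to compound 3 (0.10 log units; within the scatter) separates the two aryl variants. Compound 4 `COc1ccc(C(=O)/C=C/c2ccc(N(C)C)cc2)c(O)c1` makes a different change: hydrogen in place of 2-(diethylamino)ethyl on a saturated chain carbon bound to an oxygen on an aromatic ring. For the measured compounds named here, no measured step removes the amine-bearing chain outright; the two known steps only show that enlarging the group on the amine nitrogen of compound 1 gives modestly higher numbers. Given that, a step of similar modest size toward a higher number is expected, a 1.7-fold higher number from compound 1 to compound 4 (0.23 log units; within the scatter), with wide uncertainty. Compound 4 is therefore estimated at 7000 nM, within 2500 nM to 20000 nM.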

Compound 4, half-maximal inhibitory concentration: 210 nM
For compound 4 the middle estimate is 33-fold (1.52 log units) above the measured one; the measured number lies below the stated range.
By their numbers in this assay, from the lowest: compound 4; then compound 1; then compounds 2 and 3 (each within the scatter of the next).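

Replacing 3-(diethylamino)propoxy with methoxy gives a 20-fold lower number from compound 1 to compound 4 (1.29 log units; beyond the scatter) in this assay, so the amine-bearing chain is not needed for inhibition in this series. The earlier steps shown here changed only a group on the amine nitrogen and stayed modest, whereas this change to the chain itself is much larger and runs the other way. No measurement available here bears on why the step is so large.

From the compounds shown here alone, whether the lower number follows from losing the amine or from shortening the chain stays open: a propoxy or 3-methoxypropoxy group in place of methoxy would separate the two. A free hydroxyl in the same place would show whether even the methyl is required.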